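From 2-methoxyphenyl to tert-butoxycarbonyl on a ring nitrogen

The source may hold more compounds than are shown below. What is called first, only, known or untested is meant among the compounds shown, and "the series" means these compounds.

In a functional assay on HL-60 cells (Homo sapiens) for cytotoxicity, read by MTT assay, with a stated time of 24 h (a higher number here means a weaker inhibitor, a lower number a stronger inhibitor), compound 1 `CN1CCN(CCCCCOc2c(Br)cc(Br)cc2Oc2ccc(Br)cc2Br)CC1` gives 48.3 ug/mL and compound 2 `Brc1ccc(Oc2cc(Br)cc(Br)c2OCCCCCN2CCN(c3ccccc3)CC2)c(Br)c1` gives 41.6 ug/mL while compound 3 `COc1ccccc1N1CCN(CCCCCOc2c(Br)cc(Br)cc2Oc2ccc(Br)cc2Br)CC1` gives 32.2 ug/mL and so stands level with both within the scatter. Compound 4 `CC(C)(C)OC(=O)N1CCN(CCCCCOc2c(Br)cc(Br)cc2Oc2ccc(Br)cc2Br)CC1` carries tert-butoxycarbonyl in place of 2-methoxyphenyl on an amine nitrogen in a ring on the same core. The measured steps that bear on this change are a 1.2-fold lower number from compound 1 to compound 2 (0.06 log units; within the scatter) and a 1.5-fold lower number from compound 1 to compound 3 (0.18 log units; within the scatter) and a 1.3-fold lower number from compound 2 to compound 3 (0.11 log units; within the scatter) and all of them stay within the scatter. Among the measured compounds shown here, no measured compound carries a carbonyl on that nitrogen, so the range must stay wide. In this assay no step beyond the scatter is expected, and the estimated step is a 1.2-fold higher number from compound 3 to compound 4 (0.09 log units; within the scatter) in size. For compound 4 the expected value is 40 ug/mL with an estimated range of 22 ug/mL to 72 ug/mL around it.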

Compound 4, half-maximal inhibitory concentration: 32.1 ug/mL
Compound 4: middle estimate off by 1.2-fold (0.10 log units), on the high side, and the stated range covers the measured number.
By their numbers in this assay, from the lowest: compounds 4, 3, 2 and 1 (each within the scatter of the next).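

In this assay, tert-butoxycarbonyl, which has no ring and adds a double bond outside aromatic rings, gives a 1.0-fold lower number from compound 3 to compound 4 (0.00 log units; within the scatter) and stays within the scatter in the other two steps as well, a 1.3-fold lower number from compound 2 to compound 4 (0.11 log units; within the scatter) and a 1.5-fold lower number from compound 1 to compound 4 (0.18 log units; within the scatter). The ring nitrogen therefore now carries a carbonyl-bearing group as well as methyl, phenyl and 2-methoxyphenyl, and no step among these four compounds goes beyond the scatter. No available evidence explains this flat picture. From the compounds shown here alone, whether a chain ending in a carboxylic acid or an amine on that nitrogen would move the number beyond the scatter stays open.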